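A few compounds are considered here, and "the series" means these few. Any claim that something is new, unique, unknown or untested is made for them only; others in the source may bear on it.

In a physicochemical assay for solubility, in phosphate buffer, at pH 6.5 (a lower number here means a less soluble compound, a higher number a more soluble compound), compound 1 `C=C[C@@H]1C[C@]1(NC(=O)[C@@H]1C[C@@H](Oc2nccc3cc(OC)ccc23)CN1C(=O)[C@@H](NC(=O)NC(C)(C)C)C(C)(C)C)C(=O)NS(=O)(=O)C1CC1`, which carries a tert-butyl on an amide-type nitrogen, gives 13 ug/mL. Placing 1-(methoxymethyl)propyl on that nitrogen instead gives compound 2 `C=C[C@@H]1C[C@]1(NC(=O)[C@@H]1C[C@@H](Oc2nccc3cc(OC)ccc23)CN1C(=O)[C@@H](NC(=O)N[C@@H](CC)COC)C(C)(C)C)C(=O)NS(=O)(=O)C1CC1`, at 500 ug/mL, a large move: a 38-fold higher number from compound 1 to compound 2 (1.59 log units; beyond the scatter). Placing 1-(methoxymethyl)-2,2-dimethylpropyl there gives compound 3 `C=C[C@@H]1C[C@]1(NC(=O)[C@@H]1C[C@@H](Oc2nccc3cc(OC)ccc23)CN1C(=O)[C@@H](NC(=O)N[C@H](COC)C(C)(C)C)C(C)(C)C)C(=O)NS(=O)(=O)C1CC1`, at 609 ug/mL, again a large move: a 47-fold higher number from compound 1 to compound 3 (1.67 log units; beyond the scatter). Compound 3 therefore stands far from compound 1, but it cannot be told apart from compound 2, as the comparison shows: a 1.2-fold higher number from compound 2 to compound 3 (0.09 log units; within the scatter).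

Compound 4 `C=C[C@@H]1C[C@]1(NC(=O)[C@@H]1C[C@@H](Oc2nccc3cc(OC)ccc23)CN1C(=O)[C@@H](NC(=O)N[C@H](COC)CC(C)C)C(C)(C)C)C(=O)NS(=O)(=O)C1CC1` has the same atoms as compound 3, joined differently: isobutyl in place of tert-butyl on a saturated chain carbon bound to an amide-type nitrogen and a saturated chain carbon. Isobutyl takes the place of tert-butyl on a saturated chain carbon bound to an amide-type nitrogen and a saturated chain carbon. The two large steps replaced the tert-butyl on the nitrogen, so they do not describe this change. The closer guide is the swap at the same carbon that links compound 2 and compound 3, which was small: a 1.2-fold higher number from compound 2 to compound 3 (0.09 log units; within the scatter). Among the measured compounds shown here, no measured compound carries an isobutyl, so this guide is only indirect.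

For compound 4, the step expected in this assay stays within the scatter: a 1.2-fold lower number from compound 3 to compound 4 (0.09 log units; within the scatter). The estimated value for compound 4 is 500 ug/mL, with an expected range of 230 ug/mL to 1000 ug/mL.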

Compound 4, solubility: 225 ug/mL
Beside the measured number, compound 4's estimate is 2.2-fold (0.35 log units) above it; measured number outside the range, below it.
By their numbers in this assay, from the lowest: compound 1; then compound 4; then compounds 2 and 3 (each within the scatter of the next).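

On a saturated chain carbon bound to an amide-type nitrogen and a saturated chain carbon, the earlier swap of ethyl for tert-butyl had shown no difference beyond the scatter, but in this assay simply rearranging the same carbons from tert-butyl into isobutyl does register (a 2.7-fold lower number from compound 3 to compound 4 (0.43 log units; beyond the scatter)). The isobutyl compound also separates from the compound carrying the smaller ethyl group (a 2.2-fold lower number from compound 2 to compound 4 (0.35 log units; beyond the scatter)), so this carbon is not indifferent to what it carries, yet much of the rise over the plain tert-butyl on the amide-type nitrogen remains (a 17-fold higher number from compound 1 to compound 4 (1.24 log units; beyond the scatter)). Nothing available explains why these two arrangements of the same atoms differ.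

The compounds shown leave open whether the shape of the branching matters in general, since an unbranched butyl chain or a cyclopropyl group on this carbon would test that directly. They also leave open how an amine or a carboxylic acid at this carbon would compare with the isobutyl and tert-butyl groups.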